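A few compounds are considered here, and "the series" means these few. Any claim that something is new, unique, unknown or untested is made for them only; others in the source may bear on it.

Compound 3 `CN(C)c1cc(-c2nc(C(c3ccc(F)cc3)c3ccc(F)cc3)sc2CC(=O)O)ccn1` stands highest of the three compounds measured in an in vitro assay on HEK385-7 cells for displacement of a labelled ligand from prostaglandin D2 receptor 2 (Homo sapiens) (a lower number here means a stronger inhibitor, a higher number a weaker inhibitor), where compound 3 gives 380 nM. Compound 1 `O=C(O)Cc1sc(C(c2ccc(F)cc2)c2ccc(F)cc2)nc1-c1ccccc1` gives 16 nM, and compound 2 `NS(=O)(=O)c1cccc(-c2nc(C(c3ccc(F)cc3)c3ccc(F)cc3)sc2CC(=O)O)c1` gives 140 nM. The steps already seen all concern the aryl group on the shared core: an 8.8-fold higher number from compound 1 to compound 2 (0.94 log units; beyond the scatter), a 24-fold higher number from compound 1 to compound 3 (1.38 log units; beyond the scatter) and a 2.7-fold higher number from compound 2 to compound 3 (0.43 log units; beyond the scatter). Compound 4 `O=C(O)Cc1sc(C(c2ccc(F)cc2)c2ccc(F)cc2)nc1-c1ccnc(N2CCC2)c1` differs from compound 3 only at that ring: azetidin-1-yl in place of dimethylamino on an aromatic carbon. Going by the values given here, no measured step varies a substituent on that ring, so the exchanges of whole aryl groups give only a loose guide; swapping one small amine for another is expected to move this assay little, if at all beyond the scatter. Compound 4 is therefore estimated at 300 nM, within 120 nM to 800 nM, meaning a 1.3-fold lower number from compound 3 to compound 4 (0.10 log units; within the scatter).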

Compound 4, half-maximal inhibitory concentration: 660 nM
Compound 4: the middle estimate sits 2.2-fold (0.34 log units) below what was measured; the measured number falls inside the stated range.
By their numbers in this assay, from the lowest: compound 1; then compound 2; then compounds 3 and 4 (each within the scatter of the next).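

In this assay, going by these compounds alone, the exchange of azetidin-1-yl for dimethylamino next to the ring nitrogen, the first measured change of a substituent on that ring, gives a 1.7-fold higher number from compound 3 to compound 4 (0.24 log units; within the scatter) and so leaves the number within the scatter. The 2-(azetidin-1-yl)pyridin-4-yl group keeps the distance from the other aryl groups, with a 41-fold higher number from compound 1 to compound 4 (1.62 log units; beyond the scatter) and a 4.7-fold higher number from compound 2 to compound 4 (0.67 log units; beyond the scatter) as its steps. Nothing shown here explains these steps. Still open, on these data alone, is whether a pyrrolidin-1-yl, a primary amine or a methyl at that position would behave like these two small amines, or whether hydrogen there would bring the number closer to that of compound 1.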